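Swapping the methyl between two nitrogens of a sulfamide

The source may report more compounds than this note shows. Statements on the series, on what has been measured and on what is new or still open speak of the compounds shown alone.

Compound 2 `CN(C[C@@H]1CCCc2cc(S(=O)(=O)c3cccc(F)c3)ccc21)S(N)(=O)=O` has the highest number of the two compounds measured in an assay on isolated protein for displacement of a labelled ligand from 5-hydroxytryptamine receptor 6 (Homo sapiens); on this read-out lower numbers stand for stronger inhibition and higher numbers for weaker inhibition: in this assay compound 2 gives 3.98 nM. For the measured compounds named here, its only measured neighbour is compound 1 `NC[C@@H]1CCCc2cc(S(=O)(=O)c3cccc(F)c3)ccc21`, which in this assay gives 0.0794 nM. Going by the values given here, the one known step, a 50-fold higher number from compound 1 to compound 2 (1.70 log units; beyond the scatter), shows that replacing the bare amino group of compound 1 with the methyl(sulfamoyl)amino group costs a great deal of binding strength.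

Compound 3 `CNS(=O)(=O)NC[C@@H]1CCCc2cc(S(=O)(=O)c3cccc(F)c3)ccc21` is built from the same atoms as compound 2, joined differently: (methylsulfamoyl)amino in place of methyl(sulfamoyl)amino on a saturated chain carbon bound to a saturated ring carbon. The methyl moves from the nitrogen bound to the chain to the outer nitrogen, so the nitrogen on the chain carries a hydrogen again, and the count of hydrogen-bond donors rises by one.

Among the compounds with values here, no measured step covers this rearrangement; the single step from compound 1 to compound 2 bears only loosely, since it changes far more than a methyl position. The sulfamide is kept, so compound 3 is expected to stay far from compound 1 and close to compound 2, with a modest improvement estimated as a 2.0-fold lower number from compound 2 to compound 3 (0.30 log units; within the scatter). For compound 3 the expected value in this assay is 2 nM, within the range 0.5 nM to 10 nM.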

Compound 3, inhibition constant: 1 nM
Beside the measured number, compound 3's estimate is 2.0-fold (0.30 log units) above it, within the range that was stated.
By their numbers in this assay, from the lowest: compound 1; then compound 3; then compound 2.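

Rearranging the same atoms, with (methylsulfamoyl)amino in place of methyl(sulfamoyl)amino on a saturated chain carbon bound to a saturated ring carbon, gives in this assay a 4.0-fold lower number from compound 2 to compound 3 (0.60 log units; beyond the scatter) and so shows that binding at this position depends on where the methyl sits, not only on which atoms are present. The gain is only partial: set against the earlier loss of a 50-fold higher number from compound 1 to compound 2 (1.70 log units; beyond the scatter) when the bare amino group was replaced, the rearranged group still leaves a 13-fold higher number from compound 1 to compound 3 (1.10 log units; beyond the scatter) and keeps the sulfamide-bearing compounds well short of the amine. The entering group counts more hydrogen-bond donors than the leaving one, but no measurement shown connects that difference to the shift in binding.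

As far as these compounds go, what remains open is how a plain sulfamoyl on the amine nitrogen, with no methyl at all, would compare, and whether a dimethylsulfamoyl group would fall further behind. An acetyl or methanesulfonyl group on the same nitrogen would also show whether the loss against compound 1 belongs to the sulfamide specifically or to any such group placed on that amine.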